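The compounds below may be only part of what the source reports. "The series", "measured", "known", "first", "only" and "open" are said of these compounds alone.

Working notes on the series.

The shared core carries a pendant aryl group at one end and an aromatic carbon of the fused two-ring system at the other. Compound 1 `COc1ccc(C2=NN(C3=NC(=O)/C(=C4\C(=O)Nc5ccc(Br)cc54)S3)C(c3ccc(OC)cc3)C2)cc1` has bromo on that fused system and a methoxy-bearing pendant aryl; in a functional assay on cells (Cancer cell lines, Homo sapiens) for cytotoxicity, read by sulforhodamine B assay, with a stated time of 48 h (a higher number here means a weaker inhibitor of growth, a lower number a stronger inhibitor of growth), compound 1 gives 710 nM. Compound 2 `COc1ccc(C2=NN(C3=NC(=O)/C(=C4\C(=O)Nc5ccccc54)S3)C(c3ccc(Cl)cc3)C2)cc1` lacks the bromo and carries a chloro-bearing pendant aryl; in this assay compound 2 gives 100000 nM. Compound 2 stands at the highest of the two numbers measured, and its nearest neighbour, compound 1, lies far lower, a gap well beyond the scatter. Compounds 1 and 2 differ in two places at once, so no single step can be read between them.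

Compound 3 `COc1ccc(C2=NN(C3=NC(=O)/C(=C4\C(=O)Nc5ccc(Br)cc54)S3)C(c3ccc(Cl)cc3)C2)cc1` is compound 2 with bromo in place of hydrogen on an aromatic carbon. Within the data shown here, because compound 1, the only bromo-bearing member, gives 710 nM, a sizeable fall in the number is expected on this step, though the concurrent pendant-aryl difference leaves its size uncertain. The step is estimated as a 20-fold lower number from compound 2 to compound 3 (1.30 log units; beyond the scatter). In this assay compound 3 is expected to give about 5000 nM, in the range 600 nM to 50000 nM.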

Compound 3, concentration for total growth inhibition: 1010 nM
For compound 3 the middle estimate is 5.0-fold (0.69 log units) above the measured one; the range from low to high includes it.
By their numbers in this assay, from the lowest: compounds 1 and 3 (each within the scatter of the next); then compound 2.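

Bromo in place of hydrogen, on an aromatic carbon of the fused two-ring system and with the chloro-bearing pendant aryl held constant, can now be read as a single change: in this assay it gives a 99-fold lower number from compound 2 to compound 3 (2.00 log units; beyond the scatter) and is a large step, so this carbon strongly affects the read-out in this pair. Among these compounds, with bromo held constant, chloro in place of methoxy on the pendant aryl gives a 1.4-fold higher number from compound 1 to compound 3 (0.15 log units; within the scatter) and therefore does not separate these two compounds, leaving the bromo step as the only change beyond the scatter among the steps that can be read so far. No measurement at hand accounts for the size of the bromo step.

The compounds shown leave open whether the bromo step has a similar size with the methoxy-bearing pendant aryl, as compound 1 has no partner here that carries hydrogen on that carbon. They also leave open how an amine or a carboxylic acid on the same aromatic carbon would compare with bromo.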